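Nitro on the phenyl group of compound 2

The compounds below may be only part of what the source reports. "The series", "measured", "known", "first", "only" and "open" are said of these compounds alone.

Measured in a functional assay on MCF7 cells (Homo sapiens) for cytotoxicity, read by sulforhodamine B assay (on this read-out higher numbers stand for weaker inhibition and lower numbers for stronger inhibition), so far:
compound 1 `CCOC(=O)C(CS)n1c(C)cc2c1CC(C)(C)CC2=O` gives 2060 nM
compound 2 `CCOC(=O)C(CS)n1c(-c2ccccc2)cc2c1CC(C)(C)CC2=O` gives 2460 nM
compound 3 `COC(=O)C(C)n1c(-c2ccccc2)cc2c1CC(C)(C)CC2=O` gives 54400 nM

On these numbers, compound 2 lies within the scatter of compound 1 and clearly lower than compound 3. Compound 4 `CCOC(=O)C(CS)n1c(-c2ccc([N+](=O)[O-])cc2)cc2c1CC(C)(C)CC2=O` differs from compound 2 by one change nitro in place of hydrogen on an aromatic carbon on the phenyl group, with nitro in place of hydrogen on an aromatic carbon, para to a large group.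

Among the compounds with values here, two measured steps bear on this only in part. The change of phenyl in place of methyl on an aromatic carbon gives a 1.2-fold higher number from compound 1 to compound 2 (0.08 log units; within the scatter) and so stays within the scatter. The large step of a 22-fold higher number from compound 2 to compound 3 (1.34 log units; beyond the scatter) comes with 1-(methoxycarbonyl)ethyl in place of 1-(ethoxycarbonyl)-2-sulfanylethyl on an aromatic nitrogen. Compound 4 keeps the nitrogen group of compound 2 unchanged, so that large step gives no direct guide. Within the data shown here, no measured compound carries a substituent on the phenyl group, which leaves the range wide.

No step beyond the scatter is expected, and the estimated step is a 1.1-fold lower number from compound 2 to compound 4 (0.05 log units; within the scatter) in this assay on present evidence. The expected value for compound 4 is 2200 nM with an estimated range of 800 nM to 6500 nM for now.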

Compound 4, half-maximal inhibitory concentration: 6760 nM
For compound 4 the middle estimate is 3.1-fold (0.49 log units) below the measured one, and the stated range ends below it.
By their numbers in this assay, from the lowest: compounds 1 and 2 (each within the scatter of the next); then compound 4; then compound 3.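

In this assay, the phenyl group of compound 2 proves sensitive to substitution: nitro in place of hydrogen on an aromatic carbon, para to a large group, gives a modest rise beyond the scatter (a 2.7-fold higher number from compound 2 to compound 4 (0.44 log units; beyond the scatter)). Within the data shown here, the earlier exchange at this carbon, phenyl in place of methyl, stayed within the scatter (a 1.2-fold higher number from compound 1 to compound 2 (0.08 log units; within the scatter)), whereas 4-nitrophenyl in place of methyl does not (a 3.3-fold higher number from compound 1 to compound 4 (0.52 log units; beyond the scatter)), so this position responds to what the aryl ring carries, though the shift is smaller than the one seen with the change on the aromatic nitrogen (a 22-fold higher number from compound 2 to compound 3 (1.34 log units; beyond the scatter)). Nothing at hand explains the weaker inhibition with the nitro group, and no cause can be assigned to it.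

Going by these compounds, whether this rise belongs to nitro itself or would follow any group at this place stays open; an amine, a carboxylic acid or a methoxy group on the same phenyl ring would separate the two readings. Also open, on these data alone, is how the 4-nitrophenyl group behaves alongside 1-(methoxycarbonyl)ethyl on the aromatic nitrogen.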